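Methoxy for nitro on a sulfonamide-bearing thiazolidinone core

This account rests on a few compounds, and the source may have more. Where it says the series, first, only, none or still open, it means among the compounds named here.

Measured compounds:
compound 1, `NS(=O)(=O)c1ccc(/N=C2\NC(=O)/C(=C3/C(=O)Nc4ccc([N+](=O)[O-])cc43)S2)cc1`, 13800 nM
compound 2, `NS(=O)(=O)c1cccc(/N=C2\NC(=O)/C(=C3/C(=O)Nc4ccc([N+](=O)[O-])cc43)S2)c1`, 20600 nM
compound 3, `COc1ccc2c(c1)/C(=C1/S/C(=N/c3ccc(S(N)(=O)=O)cc3)NC1=O)C(=O)N2`, 98300 nM

All three were tested in a functional assay on Caco-2 cells (Homo sapiens) for antiproliferative activity, read by MTT assay; on this read-out higher numbers stand for weaker inhibition and lower numbers for stronger inhibition. Compound 1 and compound 2 share the same atoms joined differently: 3-sulfamoylphenyl in place of 4-sulfamoylphenyl on a double-bonded nitrogen. Their values sit close together, with a 1.5-fold higher number from compound 1 to compound 2 (0.17 log units; within the scatter). Compound 3 arises from compound 1 by a single change, (methoxy in place of nitro on an aromatic carbon), and this step gave a 7.1-fold higher number from compound 1 to compound 3 (0.85 log units; beyond the scatter).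

Compound 4, `COc1ccc2c(c1)/C(=C1/S/C(=N/c3cccc(S(N)(=O)=O)c3)NC1=O)C(=O)N2`, has not yet been measured in this assay. It stands to compound 2 as compound 3 stands to compound 1: methoxy in place of nitro on an aromatic carbon. The place line is the same word for word, so this is the same change made on the other core. Because the earlier step is a 7.1-fold higher number from compound 1 to compound 3 (0.85 log units; beyond the scatter), a step of about the same size is expected here, and the estimated step is a 6.8-fold higher number from compound 2 to compound 4 (0.83 log units; beyond the scatter). Compound 4 is therefore expected to give around 140000 nM, between 60000 nM and 350000 nM. This rests on a single earlier step, so the expectation is uncertain.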

Compound 4, half-maximal inhibitory concentration: 8390 nM
For compound 4 the middle estimate is 17-fold (1.22 log units) above the measured one; measured number below the stated range.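

In this assay, methoxy in place of nitro does not behave alike on the two cores, and on the core of compound 2 the number moves in the opposite direction to the earlier step, with a 2.5-fold lower number from compound 2 to compound 4 (0.39 log units; beyond the scatter). Set side by side, the two steps differ by more than repeat measurements would explain: the same change on two cores in this assay, a 7.1-fold higher number (0.85 log units; beyond the scatter) from compound 1 to compound 3 and a 2.5-fold lower number (0.39 log units; beyond the scatter) from compound 2 to compound 4, 17-fold (1.24 log units) apart, beyond the scatter of two such steps. The two cores differ only as 3-sulfamoylphenyl and 4-sulfamoylphenyl, so a step read on one of them cannot be assumed to hold on the other, but two pairs of compounds do not show why the steps part or how any other change would carry over.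

The compounds shown leave open whether another group on the same aromatic carbon, such as an amine or a chlorine atom, would also give steps that differ between the two cores. They also leave open whether the split would remain with a carboxylic acid in place of the sulfamoyl group.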